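Second Methoxy on the Amide Aryl Ring

The compounds below may be only part of what the source reports. "The series", "measured", "known", "first", "only" and "open" are said of these compounds alone.

For the measured compounds named here, in a functional assay on HeLa cells (Homo sapiens) for antiproliferative activity, read by CCK-8 assay, with a stated time of 72 h (on this read-out lower numbers stand for stronger inhibition and higher numbers for weaker inhibition), compound 2 `COc1cccc(C(=O)Nc2cccc(-c3oc4cc(-c5ccc(F)cc5)ccc4c(=O)c3O)c2)c1` gives 5650 nM, the lower of the two numbers measured so far. Compound 1 `O=C(Nc1cccc(-c2oc3cc(-c4ccc(F)cc4)ccc3c(=O)c2O)c1)c1ccc(Br)cc1` gives 9740 nM. Going by the values given here, the one step measured, a 1.7-fold lower number from compound 1 to compound 2 (0.24 log units; within the scatter), came with 3-methoxyphenyl replacing 4-bromophenyl on the carbonyl carbon. Compound 3 `COc1cc(OC)cc(C(=O)Nc2cccc(-c3oc4cc(-c5ccc(F)cc5)ccc4c(=O)c3O)c2)c1` carries methoxy in place of hydrogen on an aromatic carbon. Among the compounds with values here, since the only step on this same aryl ring stayed within the scatter, a second methoxy is expected to move this assay little, if at all. Compound 3 is therefore estimated at 4500 nM, in a range of 1800 nM to 12000 nM, which means an expected step of a 1.3-fold lower number from compound 2 to compound 3 (0.10 log units; within the scatter).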

Compound 3, half-maximal inhibitory concentration: 2700 nM
Compound 3: the middle estimate sits 1.7-fold (0.22 log units) above what was measured; the range from low to high includes it.
By their numbers in this assay, from the lowest: compound 3; then compounds 2 and 1 (each within the scatter of the next).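

In this assay, for the compounds shown here, methoxy in place of hydrogen on the 3-methoxyphenyl ring gave the first step on this amide aryl ring to lie beyond the scatter (a 2.1-fold lower number from compound 2 to compound 3 (0.32 log units; beyond the scatter)), though it is modest. The 3,5-dimethoxyphenyl group also stands apart from the 4-bromophenyl group (a 3.6-fold lower number from compound 1 to compound 3 (0.56 log units; beyond the scatter)), a separation that the single methoxy did not show. No measurement given here accounts for this gain. The compounds shown leave open whether the second methoxy itself matters or whether an ethoxy, a hydroxyl or an amine on that carbon would serve equally.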